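Nitro for dimethylamino on a selenazole-thiadiazole imine scaffold

This account rests on a few compounds, and the source may have more. Where it says the series, first, only, none or still open, it means among the compounds named here.

Measured compounds:
compound 1 `COc1cc(/C=N/c2nnc(SCc3c[se]c(-c4ccccc4)n3)s2)ccc1O` — > 100000 nM
compound 2 `CN(C)c1ccc(/C=N/c2nnc(SCc3c[se]c(-c4ccccc4)n3)s2)cc1` — > 100000 nM

Compound 1 `COc1cc(/C=N/c2nnc(SCc3c[se]c(-c4ccccc4)n3)s2)ccc1O` was tested in a functional assay on L1210 cells (Mus musculus) for antiproliferative activity, read by CCK-8 assay; a higher number here means a weaker inhibitor, a lower number a stronger inhibitor. In this assay compound 1 gives only a limit, > 100000 nM. Compound 2 `CN(C)c1ccc(/C=N/c2nnc(SCc3c[se]c(-c4ccccc4)n3)s2)cc1` carries a 4-(dimethylamino)phenyl in place of the 4-hydroxy-3-methoxyphenyl on the carbon with a double bond to nitrogen. In this assay compound 2 also gives only a limit, > 100000 nM. The step that the two limits leave unreadable from compound 1 to compound 2 cannot be sized, because the limit of > 100000 nM in this assay, at which 2 of the 2 values shown sit, holds every value shown so far. Compound 2 therefore stands at that limit, with nothing to rank it against.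

Compound 3 `O=[N+]([O-])c1ccc(/C=N/c2nnc(SCc3c[se]c(-c4ccccc4)n3)s2)cc1` has not been measured. It differs from compound 2 by nitro in place of dimethylamino on an aromatic carbon. No measured step bears directly on this exchange; the only step shown is unreadable, so the data give no direction and no size. Compound 3 is expected to sit again at or near the limit, an estimated step of a number no higher from compound 2 to compound 3 (the limit leaves the size open). The estimate for compound 3 in this assay is 100000 nM, within a range from 20000 nM to 300000 nM, with a high chance that only a limit is reported.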

Compound 3, half-maximal inhibitory concentration: > 100000 nM
Compound 3: no number, only a limit; the forecaster's own chance of this, stated with the estimate: 70%; the middle value lies on the limit itself.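

In this assay compound 3 gives only a limit, > 100000 nM. The steps to compound 3 from compound 1 and compound 2 cannot be read, because all three compounds sit at the same limit: the limit of > 100000 nM in this assay, at which 3 of the 3 values shown sit.

The compounds shown leave open whether 4-nitrophenyl, 4-(dimethylamino)phenyl and 4-hydroxy-3-methoxyphenyl differ at all in this assay.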